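A few compounds are considered here, and "the series" means these few. Any claim that something is new, unique, unknown or untested is made for them only; others in the source may bear on it.

Measured in a functional assay on LNCaP cells (Homo sapiens) for antiproliferative activity; on this read-out lower numbers stand for stronger inhibition and higher numbers for weaker inhibition:

compound 1 `Cn1ncc(Cl)c1-c1cc(C(=O)N[C@@H]2CN[C@H](CC(=O)NC3CC3)C[C@H]2c2ccc(Cl)c(Cl)c2)oc1Cl`: 190 nM
compound 2 `C=CC[C@@H]1C[C@@H](c2ccc(Cl)c(Cl)c2)[C@H](NC(=O)c2cc(-c3c(Cl)cnn3C)c(Cl)o2)CN1`: 160 nM
compound 3 `Cn1ncc(Cl)c1-c1cc(C(=O)N[C@@H]2CN[C@H](CC(O)CO)C[C@H]2c2ccc(F)c(F)c2)oc1Cl`: 100 nM

Compound 2 stands second highest of the three numbers. Its nearest neighbour is compound 1, the furthest is compound 3, but both gaps are within the scatter, so the three compounds cannot be put in order on these data.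

Compound 4 `CNC(=O)C[C@@H]1C[C@@H](c2ccc(Cl)c(Cl)c2)[C@H](NC(=O)c2cc(-c3c(Cl)cnn3C)c(Cl)o2)CN1` has not yet been measured. It differs from compound 2 in one place: methylcarbamoyl in place of vinyl on a saturated chain carbon bound to a saturated ring carbon.

Going by the values given here, only one measured step bears on this change. The step of a 1.2-fold lower number from compound 1 to compound 2 (0.07 log units; within the scatter) exchanges a carbamoyl group for vinyl at the same saturated chain carbon and stays within the scatter. Compound 4 makes the opposite exchange, putting a carbamoyl group back in place of vinyl, with methylcarbamoyl instead of the cyclopropylcarbamoyl of compound 1. On that single step, no movement beyond the scatter is expected for compound 4, and the expected step is a 1.1-fold higher number from compound 2 to compound 4 (0.03 log units; within the scatter).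

Among the compounds with values here, the estimate for compound 4 in this assay is therefore 170 nM, with a range from 80 nM to 360 nM; the width reflects that only one related step is available and that compound 3 carries a different aryl group, so it gives no direct guidance.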

Compound 4, half-maximal inhibitory concentration: 40 nM
Beside the measured number, compound 4's estimate is 4.3-fold (0.63 log units) above it, outside the stated range (below it).
By their numbers in this assay, from the lowest: compound 4; then compounds 3, 2 and 1 (each within the scatter of the next).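

In this assay the saturated chain carbon bound to a saturated ring carbon now proves sensitive to its substituent: methylcarbamoyl in place of vinyl gives a 4.0-fold lower number from compound 2 to compound 4 (0.60 log units; beyond the scatter) and moves beyond the scatter, whereas the earlier exchange at this place, a 1.2-fold lower number from compound 1 to compound 2 (0.07 log units; within the scatter), did not. The carbamoyl group alone does not account for the gain, since methyl in place of cyclopropyl on an amide-type nitrogen gives a 4.8-fold lower number from compound 1 to compound 4 (0.68 log units; beyond the scatter) and the step to the vinyl compound from the cyclopropylcarbamoyl compound stays within the scatter, so the group on the amide nitrogen counts in this series. Nothing in hand gives a reason for either step.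

Still open, from the compounds shown here alone, is how far this dependence runs on the amide nitrogen: the unsubstituted primary carboxamide, an ethylcarbamoyl group and a dimethylcarbamoyl group, which lacks the amide hydrogen, would each test it, and a carboxylic acid or an amine on the same chain carbon would test whether the amide is needed at all. Going by these compounds alone, also open is whether methylcarbamoyl gives a similar gain with the aryl group of compound 3 in place of the one in compound 4.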